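Ethyl ester of compound 2: what to expect

A few compounds are considered here, and "the series" means these few. Any claim that something is new, unique, unknown or untested is made for them only; others in the source may bear on it.

Measured so far in a functional assay on EA.hy 926 cells (Homo sapiens) for cytotoxicity, read by MTT assay, with stated times of 24 h and 12 h, tested at 25 uM; on this read-out higher numbers stand for a stronger effect at the one concentration tested and lower numbers for a weaker effect:
- compound 1 `COc1cc(/C=C/C(=O)O)ccc1OC(=O)c1nc(C)c(C)nc1C` gives 40.3%
- compound 2 `COc1cc(/C=C/C(=O)O)cc(OC)c1OC(=O)c1nc(C)c(C)nc1C` gives 24%

Compound 2 stands lowest of the two numbers; the step of a number 16.3 percentage points lower from compound 1 to compound 2 (beyond the scatter) separates it from compound 1. Compound 3 `CCOC(=O)/C=C/c1cc(OC)c(OC(=O)c2nc(C)c(C)nc2C)c(OC)c1` differs from compound 2 by ethyl in place of hydrogen on an oxygen next to a carbonyl group. Among the compounds with values here, no measured step concerns this place, so nothing here tells how the read-out answers to it. Within the data shown here, the only measured step, a number 16.3 percentage points lower from compound 1 to compound 2 (beyond the scatter), was modest and at another place. Compound 3 is therefore expected to land near compound 2, with a step of a number 1 percentage points higher from compound 2 to compound 3 (within the scatter) that need not exceed the scatter, at an estimated 25% (range 10% to 42%).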

Compound 3, a percentage reported as activity, at one concentration (the size of the read-out at that concentration, not a potency): 20.9%
Compound 3: middle estimate off by 4.1 percentage points, on the high side; low and high end bracket the measured number.
By their numbers in this assay, from the lowest: compounds 3 and 2 (each within the scatter of the next); then compound 1.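

In this assay, within the data shown here, the change from carboxy to ethoxycarbonyl gives a number 3.1 percentage points lower from compound 2 to compound 3 (within the scatter), the first reading at this place. Ethyl in place of hydrogen on this oxygen therefore does not separate compound 3 from compound 2 at the one concentration tested, so the free carboxy hydrogen is not required to keep this read-out. No measurement at hand explains this result. Going by these compounds, whether a longer chain or an amide at this place would read the same remains open, as does whether ethyl has the same effect on compound 1.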